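From 4-isopropylphenoxy to 2-isopropylphenoxy

This account rests on a few compounds, and the source may have more. Where it says the series, first, only, none or still open, it means among the compounds named here.

In a functional assay on HeLa cells (Homo sapiens) for cytotoxicity, read by MTT assay, with a stated time of 48 h (on this read-out higher numbers stand for an effect only at larger amounts of compound and lower numbers for an effect already at smaller amounts), compound 1 `CO[C@H]1O[C@H](COc2ccc(-c3ccccc3)cc2)[C@@H](O)[C@H](O)[C@H]1Oc1ccccc1` gives 33000 nM and compound 2 `CO[C@H]1O[C@H](COc2ccc(-c3ccccc3)cc2)[C@@H](O)[C@H](O)[C@H]1Oc1ccc(C(C)C)cc1` gives 19000 nM. These two numbers lie within the scatter of each other, so compound 2 cannot be set apart from compound 1 on the data so far.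

Compound 3 `CO[C@H]1O[C@H](COc2ccc(-c3ccccc3)cc2)[C@@H](O)[C@H](O)[C@H]1Oc1ccccc1C(C)C` has the same atoms as compound 2, joined differently: 2-isopropylphenyl in place of 4-isopropylphenyl on an oxygen on a saturated carbon. In words, this places 2-isopropylphenyl in place of 4-isopropylphenyl on an oxygen on a saturated carbon.

Among the compounds with values here, no measured step moves a group in this way, so the data offer no direct guide. Within the data shown here, the nearest evidence is the single measured step, a 1.7-fold lower number from compound 1 to compound 2 (0.24 log units; within the scatter), which puts isopropyl in place of hydrogen on an aromatic carbon. Even that introduction of the group stays within the scatter, so a change beyond the scatter is not expected from moving it, though this remains uncertain.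

The expected change is small, a 1.2-fold higher number from compound 2 to compound 3 (0.06 log units; within the scatter). For compound 3 the estimated value is 22000 nM, with an expected range from 10000 nM to 45000 nM.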

Compound 3, half-maximal effective concentration: 29000 nM
Estimate against measurement, compound 3: 1.3-fold (0.12 log units) below; low and high end bracket the measured number.
By their numbers in this assay, from the lowest: compounds 2, 3 and 1 (each within the scatter of the next).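

In this assay, the exchange of 4-isopropylphenyl for 2-isopropylphenyl on an oxygen on a saturated carbon gives a 1.5-fold higher number from compound 2 to compound 3 (0.18 log units; within the scatter), so on this read-out the two placements of the isopropyl group cannot be told apart. The comparison with the hydrogen-bearing parent gives a 1.1-fold lower number from compound 1 to compound 3 (0.06 log units; within the scatter), which means that neither the 4-isopropylphenoxy nor the 2-isopropylphenoxy form can be set apart from the plain phenoxy group, and the three compounds remain a single group within the scatter. Nothing measured here speaks to why these numbers fall as they do.

What the compounds shown leave open is whether a different kind of group on this phenoxy group, such as an amine or a carboxylic acid in place of the isopropyl, would give a step beyond the scatter. Going by these compounds, it is also open whether a change elsewhere on the shared core would separate compounds in a way that these isopropyl variations do not.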